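Capping a free hydroxy of compound 3 with benzyl

The source may hold more compounds than are shown below. What is called first, only, known or untested is meant among the compounds shown, and "the series" means these compounds.

In a functional assay on MCF7 cells (Homo sapiens) for cytotoxicity, in the presence of a further agent that is not named here (a lower number here means that less compound is needed, a higher number that more compound is needed for the effect), compound 3 `CCCCCCCO[C@@H]1[C@@H](O)[C@@H](OCc2ccccc2)O[C@H](CC(C)C)[C@H]1O` gives 6 ug/mL and compound 1 `CCCCCCCO[C@@H]1[C@@H](O)[C@@H](OCc2ccccc2)O[C@H](CC(C)C)[C@H]1OC` gives 7 ug/mL, so these two sit within the scatter of each other. Compound 2 `CCCCCCCO[C@@H]1[C@@H](OCc2ccccc2)[C@@H](OCc2ccccc2)O[C@H](CC(C)C)[C@H]1OCc1ccc(OC)cc1` shows > 20 ug/mL, which is a limit of the assay and not a number.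

Compound 4 `CCCCCCCO[C@H]1[C@H](O)[C@@H](CC(C)C)O[C@H](OCc2ccccc2)[C@@H]1OCc1ccccc1` changes compound 3 by putting benzyl in place of hydrogen on an oxygen on a saturated carbon, so hydroxy becomes benzyloxy: benzyl in place of hydrogen on an oxygen on a saturated carbon.

Going by the values given here, the only measured step nearby is a 1.2-fold lower number from compound 1 to compound 3 (0.07 log units; within the scatter). It concerns a smaller group on a different oxygen and stays within the scatter, so it offers little guidance here. Compound 2 already carries benzyl on this oxygen, but its other oxygens differ too, and its limit gives only a loose hint towards a higher number.

A moderate move to a higher number is therefore expected, and the estimated step is a 2.2-fold higher number from compound 3 to compound 4 (0.34 log units; beyond the scatter). In this assay, the estimate for compound 4 is 13 ug/mL, with an expected range from 6 ug/mL to 30 ug/mL.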

Compound 4, half-maximal effective concentration: 6 ug/mL
For compound 4 the middle estimate is 2.2-fold (0.34 log units) above the measured one; low and high end bracket the measured number.
By their numbers in this assay, from the lowest: compounds 3, 4 and 1 (each within the scatter of the next). At a limit, above all of these: compound 2.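

In this assay, the step gives no change at the digits printed from compound 3 to compound 4 (within the scatter), so on this oxygen a free hydroxy and a benzyl ether leave the number within the scatter, a result that the smaller methyl change from the earlier pair could not show. Going by these compounds alone, compound 2 is the one compound here that stands at a limit of the assay and not at a number: the limit of > 20 ug/mL in this assay, at which 1 of the 4 values shown sits. With hydrogen in place of 4-methoxybenzyl on one oxygen, the comparison gives an at least 3.3-fold lower number from compound 2 to compound 4 (0.52 log units; beyond the scatter), so the two benzyl groups that compound 4 shares with compound 2 do not by themselves bring the number to that limit.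

Going by these compounds, what happens with a carboxylic acid or an amine at the end of a chain on this oxygen remains open. Also open, on these data alone, is whether a longer chain there would keep the number where compound 3 and compound 4 sit.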